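From Chloro to Methoxy on the Shared Core

The source may hold more compounds than are shown below. What is called first, only, known or untested is meant among the compounds shown, and "the series" means these compounds.

Within the data shown here, in an ADME assay on microsomes from liver (Homo sapiens) for metabolic stability, read by LC-MS, with a stated time of 15 min (a lower number here means that less of the compound is left, a higher number that more of the compound is left), compound 2 `CCNC(=O)Nc1sc2cc(Cl)ccc2c1C(=O)N1CCN(C2CCN(C(=O)C(C)(C)C(F)(F)F)CC2)CC1` gives 51%, the higher of the two numbers so far, while compound 1 `CCNC(=O)Nc1sc2cc(F)ccc2c1C(=O)N1CCN(C2CCN(C(=O)C(C)(C)C(F)(F)F)CC2)CC1` gives 17%. Compound 3 `CCNC(=O)Nc1sc2cc(OC)ccc2c1C(=O)N1CCN(C2CCN(C(=O)C(C)(C)C(F)(F)F)CC2)CC1` carries methoxy in place of chloro on an aromatic carbon. Among the measured compounds shown here, the only measured step at this place is a number 34 percentage points higher from compound 1 to compound 2 (beyond the scatter), which is large and beyond the scatter. It exchanges fluoro for chloro, so it offers no direct reading for methoxy, and the expectation stays loose. A moderate drop is expected in this assay, namely a number 19 percentage points lower from compound 2 to compound 3 (beyond the scatter). For compound 3 the estimate is 32%, with an expected range of 12% to 55%.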

Compound 3, percent of the compound remaining: 29%
Compound 3: the middle estimate sits 3 percentage points above what was measured; the measured number falls inside the stated range.
By their numbers in this assay, from the lowest: compound 1; then compound 3; then compound 2.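

In this assay, methoxy gives this aromatic carbon a third distinct level, with a number 22 percentage points lower from compound 2 to compound 3 (beyond the scatter) and a number 12 percentage points higher from compound 1 to compound 3 (beyond the scatter) on the same shared core. The result therefore shows that the position separates three groups rather than two, with methoxy retaining less compound than chloro but more than fluoro. Nothing at hand gives a reason for this order. The compounds shown leave open where an amine or a longer ether such as ethoxy would fall at this carbon. They also leave open whether the same order holds when another part of the shared core changes.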